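The source may hold more compounds than are shown below. What is called first, only, known or untested is meant among the compounds shown, and "the series" means these compounds.

Notes on the series. In a functional assay for inhibition of metabotropic glutamate receptor 5 (Homo sapiens), read by FLIPR and calcium flux (on this read-out higher numbers stand for weaker inhibition and lower numbers for stronger inhibition), compound 1 `Cc1cccc(Sc2ccnc(-c3ccccn3)n2)c1` gives 2300 nM. Among the compounds with values here, compound 2 `Clc1cccc(Sc2ccnc(-c3ccccn3)n2)c1`, in this assay, gives 620 nM, the lowest of the two numbers so far; the only step known, a 3.7-fold lower number from compound 1 to compound 2 (0.57 log units; beyond the scatter), separates it from compound 1.

Compound 3 `FC(F)(F)c1cccc(Sc2ccnc(-c3ccccn3)n2)c1` differs from compound 2 by trifluoromethyl in place of chloro on an aromatic carbon, at the same place on the ring where compound 2 already differs from compound 1. Within the data shown here, no measured pair covers an exchange of chloro for trifluoromethyl; the one step that bears on the position, a 3.7-fold lower number from compound 1 to compound 2 (0.57 log units; beyond the scatter), was modest and beyond the scatter. With nothing beyond that single step to go on, the expectation for compound 3 is a number close to that of compound 2, with a step of a 1.4-fold lower number from compound 2 to compound 3 (0.14 log units; within the scatter) that is unlikely to exceed the scatter by much. Compound 3 is therefore estimated at 450 nM in this assay, with a range from 150 nM to 1500 nM.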

Compound 3, half-maximal inhibitory concentration: 550 nM
Compound 3: the middle estimate sits 1.2-fold (0.09 log units) below what was measured, and the stated range covers the measured number.
By their numbers in this assay, from the lowest: compounds 3 and 2 (each within the scatter of the next); then compound 1.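

In this assay the exchange of chloro for trifluoromethyl at this position gives a 1.1-fold lower number from compound 2 to compound 3 (0.05 log units; within the scatter), so the read-out does not separate the two groups, even though trifluoromethyl has 4 heavy atoms where chloro has 1. Trifluoromethyl in place of methyl gives a 4.2-fold lower number from compound 1 to compound 3 (0.62 log units; beyond the scatter), which shows that the change from methyl is not tied to chloro alone: among these three compounds, only compound 1 stands apart from the others. Nothing measured here accounts for this result.

On these data alone, what a smaller group such as fluoro, or a group of another kind such as an amine, a methoxy group, a nitrile or a carboxylic acid, would do at this position remains open. Also open, as far as these compounds go, is whether chloro and trifluoromethyl would stay level at other carbons of the same ring.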